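Biphenyl-type extension of a weakly cytotoxic sulfonamide series

The compounds below may be only part of what the source reports. "The series", "measured", "known", "first", "only" and "open" are said of these compounds alone.

The study concerns a set of sulfonamides built on a shared core, measured in an ADME assay on HCT-116 cells (Homo sapiens) for cytotoxicity, read by CellTiter-Glo, with a stated time of 72 h; a higher number here means a weaker inhibitor, a lower number a stronger inhibitor. Compound 1, `CCc1ccc(S(=O)(=O)N2CCC(N3CCC(C)CC3)CC2)cc1`, gives in this assay > 5000 nM, which is a limit of the assay rather than a number. Compound 2, `CC1CCN(C2CCN(S(=O)(=O)c3cccnc3)CC2)CC1`, gives in this assay > 10000 nM, again only a limit. Compound 3, `COc1cccc(S(=O)(=O)N2CCC(N3CCC(C)CC3)CC2)c1`, gives in this assay > 5000 nM, also a limit. The changes among them are therefore not readable: a step that the two limits leave unreadable from compound 1 to compound 2, a step that the two limits leave unreadable from compound 1 to compound 3 and a step that the two limits leave unreadable from compound 2 to compound 3, with the values sitting at the limit of > 10000 nM in this assay, at which 1 of the 3 values shown sits, and at the limit of > 5000 nM in this assay, at which 2 of the 3 values shown sit.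

Compound 4, `CC1CCN(C2CCN(S(=O)(=O)c3ccc(-c4ccccc4F)cc3)CC2)CC1`, differs from compound 1 by 2-fluorophenyl in place of ethyl on an aromatic carbon. Among the compounds with values here, no measured step bears directly on a change of this kind, and the three measured steps give no readable size in any direction. Compound 4 is therefore expected to remain close to compound 1, with an expected step that the limit leaves unreadable from compound 1 to compound 4. The value of compound 4 in this assay is estimated at 8000 nM, within a range from 2000 nM to 30000 nM.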

Compound 4, half-maximal inhibitory concentration: > 5000 nM
Compound 4: only a limit was reported (the forecaster's own chance of this, stated with the estimate: 70%); the middle value does not contradict the limit.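

Within the data shown here, compound 1 and compound 4 both stand only as limits in this assay, so no step between them can be read. The compounds shown leave open whether 2-fluorophenyl in place of ethyl changes the value at all, and at what concentration any of them reaches half-maximal inhibition.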